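This account rests on a few compounds, and the source may have more. Where it says the series, first, only, none or still open, it means among the compounds named here.

Compound 1 `COc1cc(OC)cc(-c2cccc(NC(=O)CCc3cccc4c3B(O)OC4)c2)c1`: 53 nM
Compound 2 `O=C(CCc1cccc2c1B(O)OC2)Nc1cccc(-c2cccc(C(F)(F)F)c2)c1`: 580 nM

In a functional assay on HCT-116 cells (Homo sapiens) for antiproliferative activity, read by MTT assay, with a stated time of 72 h (on this read-out lower numbers stand for stronger inhibition and higher numbers for weaker inhibition), compound 1 gives the lower of the two numbers, 53 nM. Compound 3 `COc1cc(OC)cc(-c2cccc(NC(=O)CCc3cccc4c3COB4O)c2)c1` has the same atoms as compound 1, joined differently: a group of 10 heavy atoms (7 carbon, 1 boron, 2 oxygen; one five-membered non-aromatic ring with 2 hetero atoms, one six-membered aromatic ring of carbon only) in place of a group of 10 heavy atoms (7 carbon, 1 boron, 2 oxygen; one five-membered non-aromatic ring with 2 hetero atoms, one six-membered aromatic ring of carbon only), on a saturated chain carbon, two bonds along the chain from a carbonyl carbon. For the measured compounds named here, the only measured step, an 11-fold higher number from compound 1 to compound 2 (1.04 log units; beyond the scatter), is a change elsewhere in the molecule, so it bears on this change only indirectly, by showing that a large step is possible. Going by the values given here, no measured step covers this place, so a higher number of similar size is expected, with wide uncertainty. The expected step is an 11-fold higher number from compound 1 to compound 3 (1.05 log units; beyond the scatter). The estimate for compound 3 is 600 nM, with an expected range of 100 nM to 3500 nM.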

Compound 3, half-maximal inhibitory concentration: 50000 nM
The estimate for compound 3 lay 83-fold (1.92 log units) below the measured number; the whole stated range lies below it.
By their numbers in this assay, from the lowest: compound 1; then compound 2; then compound 3.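

In this assay, the group on the saturated chain carbon, two bonds along the chain from a carbonyl carbon, tolerates no free rearrangement: the same atoms joined differently give a 940-fold higher number from compound 1 to compound 3 (2.97 log units; beyond the scatter) and leave compound 3 far behind. That step is larger than an 11-fold higher number from compound 1 to compound 2 (1.04 log units; beyond the scatter) on the same core, so the way this group is joined outweighs the aryl change measured elsewhere. Nothing measured here bears on what lies behind the loss. Open, going by these compounds, is whether a carboxylic acid or an amine at this place keeps the activity of compound 1, and whether a longer chain changes the result.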